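The compounds below may be only part of what the source reports. "The series", "measured", "known", "first", "only" and "open" are said of these compounds alone.

Compound 1 (`COC(=O)COc1ccc(OCc2ccc3ccccc3n2)cc1C1(c2ccccc2)CC2CCC1C2`): 290 nM
Compound 2 (`c1ccc(C2(c3cc(OCc4ccccn4)ccc3OCc3ccccn3)CC3CCC2C3)cc1`): 275 nM
Compound 3 (`O=C(Nc1cccnc1)Oc1ccc(OCc2ccccn2)c(C2(c3ccccc3)CC3CCC2C3)c1`): not yet measured

In a functional assay on blood (Homo sapiens) for inhibition (on this read-out higher numbers stand for weaker inhibition and lower numbers for stronger inhibition), compound 2 stands at 275 nM and compound 1 at 290 nM, two values within the scatter of each other. Compound 3 differs from compound 2 by one change: (pyridin-3-yl)carbamoyl in place of (pyridin-2-yl)methyl on an oxygen on an aromatic ring. This puts (pyridin-3-yl)carbamoyl in place of (pyridin-2-yl)methyl on an oxygen on an aromatic ring and adds a hydrogen-bond donor. Going by the values given here, no measured step covers this change, so only a modest step towards weaker inhibition in this assay is expected, estimated as a 1.5-fold higher number from compound 2 to compound 3 (0.16 log units; within the scatter). For compound 3 the estimated value is 400 nM, with an expected range from 120 nM to 1300 nM.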

Compound 3, half-maximal inhibitory concentration: > 3000 nM
Compound 3: only a limit was reported (the forecaster's own chance of this, stated with the estimate: 5%); at least 7.5-fold (0.87 log units) between middle value and limit.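

In this assay, (pyridin-3-yl)carbamoyl in place of (pyridin-2-yl)methyl on an oxygen on an aromatic ring gives an at least 10-fold higher number from compound 2 to compound 3 (1.03 log units; beyond the scatter). This shows that the group on this oxygen can matter strongly, which compounds 1 and 2 alone did not reveal. From the compounds shown here alone, compound 3 is reported only as a limit, so the full size of the step stays unknown: the limit of > 3000 nM in this assay, at which 1 of the 3 values shown sits.

The compounds shown do not separate the carbamoyl link from the shift in the pyridine attachment. A (pyridin-3-yl)methyl group on the same oxygen would separate the two.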